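Flipping One Ring Stereocentre in a Small Triazole Series

The source may hold more compounds than are shown below. What is called first, only, known or untested is meant among the compounds shown, and "the series" means these compounds.

Measured compounds:
compound 1, `CN1O[C@@H](n2ccnn2)C[C@@H]1CO`: 6530 nM
compound 2, `CCCc1cn([C@H]2C[C@H](CO)N(C)O2)nn1`: 3870 nM

In a functional assay on FTC-133 cells (Homo sapiens) for cytotoxicity, read by MTT assay, with a stated time of 24 h (on this read-out higher numbers stand for weaker inhibition and lower numbers for stronger inhibition), compound 1 and compound 2 give numbers within the scatter of each other, a 1.7-fold lower number from compound 1 to compound 2 (0.23 log units; within the scatter), so neither stands apart. Compound 3, `CN1O[C@H](n2ccnn2)C[C@@H]1CO`, differs from compound 1 only in configuration: the two compounds have the same atoms and bonds and differ only in configuration as drawn: 1 of 2 stereo elements differ; a stereocentre at a saturated ring carbon is drawn R in compound 1 and S in compound 3. Among the compounds with values here, the one measured step, the propyl entering at an aromatic carbon, says nothing about a change of configuration, so no measured step bears on this one. With nothing to lean on, compound 3 is expected to land near compound 1, with a wide range and a 1.0-fold lower number from compound 1 to compound 3 (0.00 log units; within the scatter). The estimate for compound 3 is 6500 nM, between 2000 nM and 25000 nM.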

Compound 3, half-maximal inhibitory concentration: 6300 nM
The estimate for compound 3 lay 1.0-fold (0.01 log units) above the measured number; measured number inside the range.
By their numbers in this assay, from the lowest: compounds 2, 3 and 1 (each within the scatter of the next).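

Turning the stereocentre at a saturated ring carbon from R to S gives, in this assay, a 1.0-fold lower number from compound 1 to compound 3 (0.02 log units; within the scatter). At this position, then, the drawn configuration moves the number no further than the scatter, which the earlier propyl step could not show. The comparison isolates that single change: the fact that compounds 1 and 3 differ only in the configuration as drawn

Still open, going by these compounds, is whether configuration at this carbon matters as little when propyl sits on the aromatic carbon, as in compound 2. Also open, on these data alone, is how a phenyl ring or a carboxylic acid at that aromatic carbon would read.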